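This account rests on a few compounds, and the source may have more. Where it says the series, first, only, none or still open, it means among the compounds named here.

Measured compounds:
compound 1, `ClCc1ccc(Cn2cnc3c(Cl)ncnc32)cc1`, 30900 nM
compound 2, `Nc1nc(Cl)c2ncn(Cc3ccc(CCl)cc3)c2n1`, 44700 nM
compound 3, `ClCc1ccccc1Cn1cnc2c(Cl)ncnc21`, 5490 nM

All three were run in a functional assay on SK-MEL-28 cells (Homo sapiens) for cytotoxicity, read by sulforhodamine B assay, with a stated time of 48 h; on this read-out higher numbers stand for weaker inhibition of growth and lower numbers for stronger inhibition of growth. Compound 2 follows from compound 1 by one change, (amino in place of hydrogen on an aromatic carbon), and that step, a 1.4-fold higher number from compound 1 to compound 2 (0.16 log units; within the scatter), stays within the scatter of this assay. Compound 3 has the same atoms as compound 1 joined differently; the difference between the two cores is not broken down here. In this assay compound 3 gives the lowest of the three numbers, and its gaps to compound 1 and to compound 2 both lie beyond the scatter.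

Compound 4, `Nc1nc(Cl)c2ncn(Cc3ccccc3CCl)c2n1`, has not yet been measured. It follows from compound 3 by amino in place of hydrogen on an aromatic carbon, the same change as from compound 1 to compound 2, with the place described in the same words. For the measured compounds named here, with only one earlier instance of this change, the expectation rests on that single step, a 1.4-fold higher number from compound 1 to compound 2 (0.16 log units; within the scatter), applied to compound 3; the estimated step is a 1.4-fold higher number from compound 3 to compound 4 (0.15 log units; within the scatter). For compound 4 in this assay the expected value is 7700 nM, with a likely range from 3000 nM to 20000 nM.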

Compound 4, concentration for total growth inhibition: 20900 nM
The estimate for compound 4 lay 2.7-fold (0.43 log units) below the measured number; measured number above the stated range.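

In this assay, amino in place of hydrogen on an aromatic carbon gives a 3.8-fold higher number from compound 3 to compound 4 (0.58 log units; beyond the scatter), and this step cannot be told apart from the earlier one on the other core: the same change on two cores in this assay, a 1.4-fold higher number (0.16 log units; within the scatter) from compound 1 to compound 2 and a 3.8-fold higher number (0.58 log units; beyond the scatter) from compound 3 to compound 4, 2.6-fold (0.42 log units) apart, within the scatter of two such steps. Read together, the two steps are compatible with a single shift carried across both cores, although only the step on the core of compound 3 lies beyond the scatter on its own. Two cores are too few to fix a size for the change or to show that it holds on any further core, and the steps do not say what drives the shift.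

Still open, on these data alone, is whether methylamino, hydroxyl or methoxy on the same aromatic carbon would give steps of similar size on both cores. Also open, as far as these compounds go, is whether the amino step would persist with the chloro group replaced by an amine such as morpholine.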